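Replacing a Cyclopropyl with a Pyrazinyl on the Amide Nitrogen

This account rests on a few compounds, and the source may have more. Where it says the series, first, only, none or still open, it means among the compounds named here.

Measured compounds:
- compound 1 `Cc1ccc(OCC(=O)N(Cc2cccs2)C2CC2)cc1`: 8 nM
- compound 2 `CCN(Cc1cccs1)C(=O)c1cc2cc(OC)ccc2o1`: 80 nM
- compound 3 `CCN(Cc1cccs1)C(=O)COc1ccccc1C`: 192 nM

Three compounds have been characterised in an assay on HEK293 cells for agonist activity at transient receptor potential cation channel subfamily M member 8 (Homo sapiens), read by fluorescence and calcium flux, with a stated time of 15 min; on this read-out higher numbers stand for an effect only at larger amounts of compound and lower numbers for an effect already at smaller amounts. Compound 1 gives 8 nM, the lowest number of the three; compound 2, at 80 nM, and compound 3, at 192 nM, both lie beyond the usual scatter from it, so compound 1 is the most potent compound of the measured set in this assay.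

The next compound, compound 4 `Cc1ccc(OCC(=O)N(Cc2cccs2)c2cnccn2)cc1`, has not yet been tested. It differs from compound 1 in one place: pyrazin-2-yl in place of cyclopropyl on an amide-type nitrogen. For the measured compounds named here, the three measured compounds share the thiophen-2-ylmethyl amide, but none of them pairs a cyclopropyl against a pyrazin-2-yl on the same amide-type nitrogen, so no measured step guides the size of this change.

The author expects compound 4 to give a somewhat higher number than compound 1 in this assay, an estimated step of a 3.1-fold higher number from compound 1 to compound 4 (0.49 log units; beyond the scatter) that is modest but probably beyond the scatter. Compound 4 is therefore estimated at 25 nM, with a range from 6 nM to 120 nM.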

Compound 4, half-maximal effective concentration: 1240 nM
Compound 4: middle estimate off by 50-fold (1.70 log units), on the low side, and the stated range ends below it.
By their numbers in this assay, from the lowest: compound 1; then compound 2; then compound 3; then compound 4.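

Pyrazin-2-yl in place of cyclopropyl on the amide-type nitrogen gives the first direct reading of this position in this assay, with a 160-fold higher number from compound 1 to compound 4 (2.19 log units; beyond the scatter). With the rest of the molecule unchanged, this single group on the nitrogen is enough to move compound 4 from the lowest region of the series to the highest number of the four, so the position is far from indifferent to this replacement. Nothing available here bears on why the step is so large.

From the compounds shown here alone, it remains open whether a phenyl on this nitrogen would track the pyrazin-2-yl or the cyclopropyl, and so whether the aromatic ring itself or its two ring nitrogens carry the step. Going by these compounds, it is equally open whether cyclobutyl or isopropyl would keep the low number of compound 1.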